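Capping the phenol of compound 3: working notes toward compound 4

The source may report more compounds than this note shows. Statements on the series, on what has been measured and on what is new or still open speak of the compounds shown alone.

compound 1 `CC(=O)NCCN(C)c1cccc(OCCCCN)c1` gives 3090 nM in an assay on cells for displacement of a labelled ligand from melatonin receptor type 1A (Homo sapiens), using the Cheng-Prusoff equation, with a stated time of 90 min; on this read-out higher numbers stand for weaker inhibition and lower numbers for stronger inhibition
compound 2 `CC(=O)NCCN(C)c1cccc(OCCCCCCN)c1` gives 447 nM in this assay
compound 3 `CC(=O)NCCN(C)c1cccc(OCCCCOc2cccc(O)c2)c1` gives 186 nM in this assay

Compound 3 carries the lowest number of the three, with compound 2 nearest and compound 1 furthest. Every lengthening of the chain terminus so far lowered the number: a 6.9-fold lower number from compound 1 to compound 2 (0.84 log units; beyond the scatter) and, more strongly, a 17-fold lower number from compound 1 to compound 3 (1.22 log units; beyond the scatter), with a 2.4-fold lower number from compound 2 to compound 3 (0.38 log units; beyond the scatter) between the two larger termini.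

Compound 4 `CC(=O)NCCN(C)c1cccc(OCCCCOc2cccc(OC(=O)NC3CCCCC3)c2)c1` differs from compound 3 only at the hydroxy terminus: cyclohexylcarbamoyl in place of hydrogen on an oxygen on an aromatic ring. Among the compounds with values here, no measured step touches this oxygen, so the change has no direct precedent. Within the data shown here, the steps that bear on it indirectly are the three terminal extensions, all of which lowered the number, by modest to large amounts. On that basis the expectation for this assay is a further small drop or no step beyond the scatter, with an upward move possible given that the phenol donor is lost. Compound 4 is therefore expected to give 130 nM, between 35 nM and 500 nM, meaning an expected 1.4-fold lower number from compound 3 to compound 4 (0.16 log units; within the scatter).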

Compound 4, inhibition constant: 34.7 nM
Compound 4: middle estimate off by 3.7-fold (0.57 log units), on the high side; the whole stated range lies above it.
By their numbers in this assay, from the lowest: compound 4; then compound 3; then compound 2; then compound 1.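

The free hydroxy hydrogen of compound 3 is not required for a low number in this assay: cyclohexylcarbamoyl in place of hydrogen on this oxygen gives a 5.4-fold lower number from compound 3 to compound 4 (0.73 log units; beyond the scatter). This oxygen on an aromatic ring therefore accepts a group of 9 heavy atoms, with a six-membered non-aromatic ring of carbon only, and the number falls rather than rises. No supporting data are available to explain this drop.

The compounds shown do not separate the contributions of the cyclohexyl ring, the carbonyl and the amide hydrogen of the new group. Still open, going by these compounds, is how a methyl ether, an acetate ester or a phenylcarbamoyl group on the same oxygen would compare with compound 4 in this assay.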